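The source may report more compounds than this note shows. Statements on the series, on what has been measured and on what is new or still open speak of the compounds shown alone.

Working notes on the series in a functional assay on HL-60 cells (Homo sapiens) for cytotoxicity, read by MTT assay, with a stated time of 3 days; on this read-out lower numbers stand for stronger inhibition and higher numbers for weaker inhibition.

The measured set is small. Compound 1 `N#Cc1c(O)nc(SCc2nc3ccccc3[nH]2)nc1-c1ccccc1` gives 2.55 nM. Compound 2 `N#Cc1c(NN)nc(SCc2nc3ccccc3[nH]2)nc1-c1ccccc1` gives 11.9 nM, and the change a 4.7-fold higher number from compound 1 to compound 2 (0.67 log units; beyond the scatter). Compound 3 `N#Cc1c(Nc2ccccc2)nc(SCc2nc3ccccc3[nH]2)nc1-c1ccccc1` gives 4.46 nM; the change a 1.7-fold higher number from compound 1 to compound 3 (0.24 log units; within the scatter), while a 2.7-fold lower number from compound 2 to compound 3 (0.43 log units; beyond the scatter). Compound 3 thus stands second highest of the three numbers, nearest to compound 1 and furthest from compound 2.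

Compound 4 `N#Cc1c(NNC(N)=S)nc(SCc2nc3ccccc3[nH]2)nc1-c1ccccc1` is not yet measured in this assay. Its difference from compound 3 is a group of 4 heavy atoms (1 carbon, 2 nitrogen, 1 sulfur; no ring) in place of a group of 6 heavy atoms (6 carbon; one six-membered aromatic ring of carbon only), on a nitrogen on an aromatic ring. The step that bears most directly on it is the one in which phenyl replaced amino on the same nitrogen, a 2.7-fold lower number from compound 2 to compound 3 (0.43 log units; beyond the scatter); compound 4 undoes that replacement and attaches instead a group of 4 heavy atoms with 2 hydrogen-bond donors and 1 hydrogen-bond acceptor. For the measured compounds named here, no measured pair shows this entering group, so how far it departs from the behaviour of compound 2 is unknown. A modest rise in the number beyond the scatter is therefore expected, on the order of the reverse of the step from compound 2 to compound 3.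

Compound 4 is estimated at 11 nM, with a range of 4 nM to 30 nM, meaning an expected step of a 2.5-fold higher number from compound 3 to compound 4 (0.39 log units; beyond the scatter).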

Compound 4, half-maximal inhibitory concentration: 4.54 nM
Beside the measured number, compound 4's estimate is 2.4-fold (0.38 log units) above it; the measured number falls inside the stated range.
By their numbers in this assay, from the lowest: compounds 1, 3 and 4 (each within the scatter of the next); then compound 2.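

In this assay, the group of 4 heavy atoms (1 carbon, 2 nitrogen, 1 sulfur; no ring) and phenyl lie within the scatter of each other on a nitrogen on an aromatic ring (a 1.0-fold higher number from compound 3 to compound 4 (0.01 log units; within the scatter)), so in this pair an aromatic ring at this place is not needed for a number of this size. The earlier compounds shown here showed a step beyond the scatter from compound 2 only with phenyl entering, whereas the group entering on the amine nitrogen gives a step of similar size (a 2.6-fold lower number from compound 2 to compound 4 (0.42 log units; beyond the scatter)). Compound 4 also lies within the scatter of the hydroxy compound (a 1.8-fold higher number from compound 1 to compound 4 (0.25 log units; within the scatter)), and no supporting measurement is at hand to explain any of these steps.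

The compounds shown leave open whether the oxygen counterpart of the entering group, with a carbonyl in place of the sulfur-bearing carbon, or an acetyl group on the same amine nitrogen would stay within the scatter of compound 4. They also leave open how a simple alkyl amine such as dimethylamino, on the same aromatic carbon, would compare with the hydroxy, anilino and substituted hydrazine-type groups.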